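Replacing the aryl substituent on a kinase binding probe

A few compounds are considered here, and "the series" means these few. Any claim that something is new, unique, unknown or untested is made for them only; others in the source may bear on it.

Compound 1 `CCCS(=O)(=O)Nc1ccc(F)c(C(=O)c2n[nH]c3ncc(-c4ccccc4C)cc23)c1F`: 7%
Compound 2 `CCCS(=O)(=O)Nc1ccc(F)c(C(=O)c2n[nH]c3ncc(-c4ccc(O)cc4)cc23)c1F`: 0.75%
Compound 3 `CCCS(=O)(=O)Nc1ccc(F)c(C(=O)c2n[nH]c3ncc(-c4ccc(Cl)c(C(F)(F)F)c4)cc23)c1F`: 15%

In an assay for binding affinity to dual specificity mitogen-activated protein kinase kinase 4 (Homo sapiens), read by KINOMEscan, tested at 100 nM (on this read-out higher numbers stand for a weaker effect at the one concentration tested and lower numbers for a stronger effect), compound 3 stands highest of the three numbers: the step from compound 1 to compound 3 is a number 8 percentage points higher from compound 1 to compound 3 (within the scatter), and the step from compound 2 to compound 3 is a number 14.3 percentage points higher from compound 2 to compound 3 (beyond the scatter). Compound 4 `CCCS(=O)(=O)Nc1ccc(F)c(C(=O)c2n[nH]c3ncc(-c4ccc(S(C)(=O)=O)cc4)cc23)c1F` has not been measured. It differs from compound 3 in one place: 4-(methylsulfonyl)phenyl in place of 4-chloro-3-(trifluoromethyl)phenyl on an aromatic carbon. Within the data shown here, the step that bears on this change is the one from compound 2, which carries 4-hydroxyphenyl, to compound 3, a number 14.3 percentage points higher from compound 2 to compound 3 (beyond the scatter); the step from compound 1 was within the scatter. The new group is a 4-substituted phenyl, so a downward step toward compound 2 is expected, about a number 11 percentage points lower from compound 3 to compound 4 (beyond the scatter). Compound 4 is therefore estimated at 4%, between 0.5% and 14%.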

Compound 4, a percentage reported as activity, at one concentration (the size of the read-out at that concentration, not a potency): 1.5%
Compound 4: middle estimate off by 2.5 percentage points, on the high side; low and high end bracket the measured number.
By their numbers in this assay, from the lowest: compounds 2, 4, 1 and 3 (each within the scatter of the next, the first and the last beyond it).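

Among these compounds, with 4-(methylsulfonyl)phenyl at this position, this assay shows a number 13.5 percentage points lower from compound 3 to compound 4 (beyond the scatter), so 4-hydroxyphenyl is no longer the only group that stands clear of 4-chloro-3-(trifluoromethyl)phenyl. Methylsulfonyl in place of hydroxy gives a number 0.8 percentage points higher from compound 2 to compound 4 (within the scatter), and the change from 2-methylphenyl gives a number 5.5 percentage points lower from compound 1 to compound 4 (within the scatter), so this change separates compound 4 from compound 3 alone, and compound 3, also substituted at the 4-position, goes against any rule based on that position. No measurement here accounts for these differences. The compounds shown leave open whether 4-chlorophenyl alone, 3-(trifluoromethyl)phenyl alone or 4-aminophenyl would read like compound 3 or like compound 4.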